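Bromo for chloro on the aryl ketone of the nitrile series

The compounds below may be only part of what the source reports. "The series", "measured", "known", "first", "only" and "open" are said of these compounds alone.

Measured compounds:
compound 1, `COC(=O)C1=C(N)Oc2c(OC)cc(Br)cc2C1CC(=O)c1ccc(Br)cc1`: 31.9%
compound 2, `COc1cc(Br)cc2c1OC(N)=C(C#N)C2CC(=O)c1ccc(Cl)cc1`: 33.3%

In a functional assay on MCF7 cells (Homo sapiens) for antiproliferative activity, read by sulforhodamine B assay, with a stated time of 72 h, tested at 30 uM (on this read-out lower numbers stand for a stronger effect and higher numbers for a weaker effect at the one concentration tested), compound 1 gives 31.9% and compound 2 gives 33.3%. Compound 2 stands with compound 1 at the same place on this read-out: the two numbers lie within the usual scatter of each other, so no order between them can be read, and neither can be called the stronger or the weaker. Within the data shown here, the two compounds differ in more than one place, so what their pair shows is only that two different cores, each carrying a halogen on the aryl ketone, land at about the same activity.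

Compound 3, `COc1cc(Br)cc2c1OC(N)=C(C#N)C2CC(=O)c1ccc(Br)cc1`, has not been measured. It differs from compound 2 in one place: bromo in place of chloro on an aromatic carbon. Among the measured compounds shown here, no step between measured compounds isolates this change, so no measured size can be set against it. On the two numbers in hand a step of no more than the scatter is expected, in either direction. The step from compound 2 to compound 3 is estimated at a number 1.3 percentage points lower from compound 2 to compound 3 (within the scatter) in this assay. For compound 3 the expected value in this assay is 32%, with a range from 20% to 45%.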

Compound 3, a percentage reported as activity, at one concentration (the size of the read-out at that concentration, not a potency): 33.1%
Estimate against measurement, compound 3: 1.1 percentage points below, within the range that was stated.
By their numbers in this assay, from the lowest: compounds 1, 3 and 2 (each within the scatter of the next).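

In this assay, the change from 4-chlorophenyl to 4-bromophenyl now has a measured size, a number 0.2 percentage points lower from compound 2 to compound 3 (within the scatter), so chloro and bromo cannot be told apart at this place, para to a large group. Compound 3 also isolates the other difference between the earlier pair: cyano in place of methoxycarbonyl on a double-bonded ring carbon, with the 4-bromophenyl held fixed, gives a number 1.2 percentage points higher from compound 1 to compound 3 (within the scatter), so this change also has no readable effect on the read-out, and the match between the two cores no longer rests only on a pair differing in more than one place. Nothing available explains why either step is so small.

From the compounds shown here alone, whether this aromatic carbon accepts a group other than a halogen, such as an amine or a carboxylic acid, remains open, as does whether a carboxylic acid or an amide at the double-bonded ring carbon would hold the same level. Going by these compounds, all three values come from a single concentration in this assay, so whether the compounds would separate on a full concentration-response read-out also remains open.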